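Adding One Trifluoromethyl to the Pyrazol-1-yl of Compound 3

The source may report more compounds than this note shows. Statements on the series, on what has been measured and on what is new or still open speak of the compounds shown alone.

Measured in an assay on cells for displacement of a labelled ligand from Glucagon receptor (Homo sapiens), in the presence of a further agent that is not named here; on this read-out lower numbers stand for stronger inhibition and higher numbers for weaker inhibition:
- compound 1, `CCCC(Oc1ccc(-n2cc3ccccc3n2)cc1)c1ccc(C(=O)NCCC(=O)O)cc1`, gives 290 nM
- compound 2, `CCCC(Oc1ccc(-n2cc(C(F)(F)F)c(C)n2)cc1)c1ccc(C(=O)NCCC(=O)O)cc1`, gives 1100 nM
- compound 3, `CCCC(Oc1ccc(-n2cccn2)cc1)c1ccc(C(=O)NCCC(=O)O)cc1`, gives 4100 nM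

Compound 3 has the highest number of the three: the gaps a 3.7-fold higher number from compound 2 to compound 3 (0.57 log units; beyond the scatter) and a 14-fold higher number from compound 1 to compound 3 (1.15 log units; beyond the scatter) both lie beyond the usual scatter, so in this assay compound 3 is the weakest of the measured set.

Compound 4, `CCCC(Oc1ccc(-n2cc(C(F)(F)F)cn2)cc1)c1ccc(C(=O)NCCC(=O)O)cc1`, differs from compound 3 in one place: trifluoromethyl in place of hydrogen on an aromatic carbon. The step that bears most directly on this change runs the other way: a 3.7-fold higher number from compound 2 to compound 3 (0.57 log units; beyond the scatter) covers the loss of both a methyl and a trifluoromethyl from that same ring. Compound 4 restores only the trifluoromethyl, so part of that step is expected to be won back, though not all of it. The steps of a 3.8-fold higher number from compound 1 to compound 2 (0.58 log units; beyond the scatter) and a 14-fold higher number from compound 1 to compound 3 (1.15 log units; beyond the scatter) compare quite different groups on that aromatic carbon and say less here. In this assay compound 4 is therefore expected to show a modest step toward a lower number, a 2.6-fold lower number from compound 3 to compound 4 (0.41 log units; beyond the scatter). The estimate for compound 4 is 1600 nM, with a range from 700 nM to 3600 nM.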

Compound 4, inhibition constant: 890 nM
For compound 4 the middle estimate is 1.8-fold (0.25 log units) above the measured one; measured number inside the range.
By their numbers in this assay, from the lowest: compound 1; then compounds 4 and 2 (each within the scatter of the next); then compound 3.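

Among these compounds, compound 3 and compound 2 differed by two groups at once, so the earlier compounds could not show which one mattered; here trifluoromethyl alone gives a 4.6-fold lower number from compound 3 to compound 4 (0.66 log units; beyond the scatter) in this assay, so this single group on the five-membered aromatic ring is enough for a clear gain. Taking away the methyl gives a 1.2-fold lower number from compound 2 to compound 4 (0.09 log units; within the scatter) and lies within the scatter, so with trifluoromethyl in place, the methyl makes no difference that this assay can resolve. Even so, a 3.1-fold higher number from compound 1 to compound 4 (0.49 log units; beyond the scatter) shows that 4-(trifluoromethyl)-1H-pyrazol-1-yl still falls short of the 2H-indazol-2-yl group of compound 1.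

No measurement here explains why trifluoromethyl has this effect. Also open, from the compounds shown here alone, is how a nitrile, a chlorine atom or a methyl alone on that same aromatic carbon would compare with trifluoromethyl, and whether any such group could match compound 1.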